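A few compounds are considered here, and "the series" means these few. Any claim that something is new, unique, unknown or untested is made for them only; others in the source may bear on it.

In a functional assay on P388 cells (Mus musculus) for antiproliferative activity (a lower number here means a stronger inhibitor, a higher number a weaker inhibitor), compound 1 `COc1ccc(S(=O)(=O)Nc2cccc3c(Cl)c[nH]c23)cc1` gives 0.76 ug/mL and compound 2 `N#Cc1ccc(S(=O)(=O)Nc2cccc3c(Cl)c[nH]c23)cc1` gives 1.4 ug/mL. These two numbers lie within the usual scatter of repeated measurements, so compound 2 cannot be ranked against compound 1. Compound 3 `NC(=O)c1ccc(S(=O)(=O)Nc2cccc3c(Cl)c[nH]c23)cc1` keeps the shared core and differs from compound 2 in one group, with carbamoyl in place of cyano on an aromatic carbon, para to a large group: carbamoyl in place of cyano on an aromatic carbon. Going by the values given here, only one measured step bears on this place, a 1.8-fold higher number from compound 1 to compound 2 (0.27 log units; within the scatter), with cyano in place of methoxy. Among the compounds with values here, that step stays within the scatter, but no measured compound carries carbamoyl, so it offers only limited guidance. No step beyond the scatter is therefore expected in this assay. The estimate means a 1.2-fold lower number from compound 2 to compound 3 (0.07 log units; within the scatter). For compound 3 the estimated value is 1.2 ug/mL, with an expected range from 0.4 ug/mL to 3.6 ug/mL.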

Compound 3, half-maximal inhibitory concentration: 0.87 ug/mL
Compound 3: the middle estimate sits 1.4-fold (0.14 log units) above what was measured; measured number inside the range.
By their numbers in this assay, from the lowest: compounds 1, 3 and 2 (each within the scatter of the next).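

Replacing cyano with carbamoyl on this aromatic carbon brings in a hydrogen-bond donor and one more heavy atom, yet in this assay the change stays within the scatter (a 1.6-fold lower number from compound 2 to compound 3 (0.21 log units; within the scatter)). Carbamoyl also cannot be separated from methoxy (a 1.1-fold higher number from compound 1 to compound 3 (0.06 log units; within the scatter)), so all three measured groups at this place, para to a large group, now read alike, although they differ in their atoms and in their hydrogen-bond donors. No measurement is available that would give a cause for this similarity.

On these data alone, whether this insensitivity extends beyond these three groups remains open: an amine, a carboxylic acid or a longer chain at the same carbon could still give a step beyond the scatter. The compounds shown also say nothing about changes elsewhere on the shared core.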